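This account rests on a few compounds, and the source may have more. Where it says the series, first, only, none or still open, it means among the compounds named here.

Compound 3, `COc1ccc2nc(-c3c(Cl)nc(N)nc3N[C@@H]3C[C@H](CO)[C@@H](O)[C@H]3O)sc2c1`, belongs to a set of three related compounds tested in an ADME assay on cells (Homo sapiens) for cytotoxicity, read by polymerase chain reaction, with a stated time of 3 days; on this read-out higher numbers stand for lower toxicity in this test and lower numbers for higher toxicity in this test. In this assay compound 3 reaches only the limit of the test, > 25000 nM, so its reading is a limit and not a number. Compound 1, `Nc1nc(Cl)c(-c2nc3ccc(F)cc3s2)c(N[C@@H]2C[C@H](CO)[C@@H](O)[C@H]2O)n1`, likewise gives a limit in this assay, namely > 25000 nM. Compound 2, `Nc1nc(Cl)c(-c2nc3ccc(Cl)cc3s2)c(N[C@@H]2C[C@H](CO)[C@@H](O)[C@H]2O)n1`, gives 16000 nM in this assay. Taken together, the set mostly stands at the limit of > 25000 nM in this assay, at which 2 of the 3 values shown sit. Because of that, the step that the two limits leave unreadable from compound 1 to compound 3 cannot be read, and an at least 1.5-fold higher number from compound 2 to compound 3 (0.19 log units; that floor lies within the scatter) carries only a floor that lies within the scatter.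

Compound 4, `CCOc1ccc2nc(-c3c(Cl)nc(N)nc3N[C@@H]3C[C@H](CO)[C@@H](O)[C@H]3O)sc2c1`, differs from compound 3 by methyl in place of hydrogen on a saturated chain carbon bound to an oxygen on an aromatic ring. Among the measured compounds shown here, none of the measured steps touches this place: an at least 1.5-fold lower number from compound 1 to compound 2 (0.19 log units; that floor lies within the scatter) exchanges the group on the aromatic carbon, and the other two steps do the same. Nothing measured therefore speaks for or against a change in this assay on going from methoxy to ethoxy, and the expectation is no step beyond the scatter, with the reading most likely again a limit. Compound 4 is thus expected to give about 25000 nM in this assay, within 12000 nM to 50000 nM. The expected step is a number no higher from compound 3 to compound 4 (the limit leaves the size open).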

Compound 4, half-maximal cytotoxic concentration: > 25000 nM
Compound 4 gave a limit, no number; the forecaster's own chance of this, stated with the estimate: 60%; the middle value lies on the limit itself.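

In this assay compound 4 gives > 25000 nM, which is a limit of the test and not a number. Among the compounds shown here, this shows that the change at this place, from methoxy to ethoxy, still leaves the reading at the limit, so the steps to compound 4 from compound 3 and from compound 1 cannot be read, and the set now gathers even more at one reading: the limit of > 25000 nM in this assay, at which 3 of the 4 values shown sit. The one step that can be read is an at least 1.5-fold higher number from compound 2 to compound 4 (0.19 log units; that floor lies within the scatter), so it does not separate the two compounds by any size beyond the usual variation between repeats.

As far as these compounds go, whether compound 3 and compound 4 differ at all in this assay stays open, as does what a longer chain such as propoxy, or an amine or a carboxylic acid in place of the ethoxy, would do to the reading. Of the compounds shown, only compound 2 gives a number, 16000 nM, so the set holds a single true measurement to compare any new group against.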